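Cytotoxicity notes on naphthyloxyacetyl hydrazones, nitrophenyl pair

The compounds below may be only part of what the source reports. "The series", "measured", "known", "first", "only" and "open" are said of these compounds alone.

The series shares a core carrying an acylhydrazone; compound 1 is `C/C(=N\NC(=O)COc1cccc2ccccc12)c1cccc([N+](=O)[O-])c1` and compound 2 is `O=C(COc1cccc2ccccc12)N/N=C/c1ccc(Br)cc1`. Going by the values given here, in an ADME assay on HEL cells (Homo sapiens) for cytotoxicity (a higher number here means that more compound is tolerated, a lower number that less compound is tolerated), compound 1 gives 20 ug/mL, and this is the only plain number available for the measured compounds. For compound 2 this assay gives > 100 ug/mL, which is a limit of the assay and not a number; the limit of > 100 ug/mL in this assay, at which 1 of the 2 values shown sits, records where that limit sits. Among the compounds with values here, no pair of measured compounds differs in one place, so no measured step is at hand. The unmeasured compound 3 is `C/C(=N\NC(=O)COc1cccc2ccccc12)c1ccc([N+](=O)[O-])cc1`; it holds the same atoms as compound 1 joined differently, with 4-nitrophenyl in place of 3-nitrophenyl on a carbon with a double bond to nitrogen. Within the data shown here, with no measured step to lean on, and the change confined to the nitrophenyl as counted, the step of a 1.3-fold higher number from compound 1 to compound 3 (0.10 log units; within the scatter) is expected to stay within the usual scatter of this assay, in no particular direction. Compound 3 is therefore estimated at 25 ug/mL in this assay, with a range from 10 ug/mL to 60 ug/mL, the upper end allowing that a limit rather than a number may be reported.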

Compound 3, minimum cytotoxic concentration: 100 ug/mL
Beside the measured number, compound 3's estimate is 4.0-fold (0.60 log units) below it; measured number above the stated range.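

This position, on a carbon with a double bond to nitrogen, responds to the placement of the nitro group within the ring: in this assay 4-nitrophenyl in place of 3-nitrophenyl gives a 5.0-fold higher number from compound 1 to compound 3 (0.70 log units; beyond the scatter) with no change in the counted atoms, rings, donors or acceptors. The step therefore shows that rearranging the same atoms in this one group is enough to move the read-out beyond the scatter, which compound 2 could not show, as it differs from compound 1 in more than one place. The number for compound 3 sits at the figure where the limit recorded for compound 2 falls, leaving little room to read further upward in this series: the limit of > 100 ug/mL in this assay, at which 1 of the 3 values shown sits.

From the compounds shown here alone, whether the higher number depends on the nitro group itself stays open, and an aminophenyl or a carboxyphenyl on the same carbon would test that. Compound 2 differs from compound 3 in more than one place, so the 4-bromophenyl and the saturated chain carbon cannot be separated in their bearing on tolerance.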